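Series notes: removing the aryl halogen on the shared core

The source may hold more compounds than are shown below. What is called first, only, known or untested is meant among the compounds shown, and "the series" means these compounds.

In a functional assay on CCRF-CEM cells (Homo sapiens) for antiproliferative activity, read by MTT assay, with a stated time of 24 h, tested at 12.5 uM (a lower number here means a stronger effect, a higher number a weaker effect of the compound at the concentration tested), compound 1 `OC(CCn1nc2c(Br)c(Br)c(Br)c(Br)c2n1)c1cccc(Br)c1` gives 102%. Within the data shown here, compound 2 `OC(CCn1nc2c(Br)c(Br)c(Br)c(Br)c2n1)c1cccc(Cl)c1` gives 110% in this assay, the highest of the two numbers so far. Among the measured compounds shown here, the only measured step, a number 8 percentage points higher from compound 1 to compound 2 (within the scatter), was small. Compound 3 `OC(CCn1nc2c(Br)c(Br)c(Br)c(Br)c2n1)c1ccccc1` differs from compound 2 by hydrogen in place of chloro on an aromatic carbon. For the measured compounds named here, that single halogen-exchange step is the only one bearing on this change, and it stayed within the scatter, so no step beyond the scatter is expected in this assay, in either direction. Compound 3 is therefore expected to give 105%, with a range from 92% to 118%. The expected step of a number 5 percentage points lower from compound 2 to compound 3 (within the scatter) is within the scatter.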

Compound 3, a percentage reported as activity, at one concentration (the size of the read-out at that concentration, not a potency): 122%
Compound 3: the middle estimate sits 17 percentage points below what was measured, and the stated range ends below it.
By their numbers in this assay, from the lowest: compounds 1 and 2 (each within the scatter of the next); then compound 3.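

In this assay, the aromatic carbon carrying the halogen now gives steps beyond the scatter: a number 12 percentage points higher from compound 2 to compound 3 (beyond the scatter) and a number 20 percentage points higher from compound 1 to compound 3 (beyond the scatter). Exchanging one halogen for the other stayed within the scatter, so across these three compounds the weaker effect goes with having no halogen at this place, not with which halogen it is. Nothing available explains this change.

As far as these compounds go, whether an amine or a carboxylic acid on this aromatic carbon would read like the halogens or like hydrogen stays open. Also open, from the compounds shown here alone, is whether a halogen elsewhere on this ring would do the same.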